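The source may hold more compounds than are shown below. What is called first, only, known or untested is meant among the compounds shown, and "the series" means these compounds.

Measured so far:
- compound 1 `O=C(/C=C/c1ccc([N+](=O)[O-])cc1)c1c(O)c2ccccc2[nH]c1=O`: > 50000 nM
- compound 2 `O=C(O)c1ccc(/C=C/C(=O)c2c(O)c3ccccc3[nH]c2=O)cc1`: > 50000 nM

In an ADME assay on THP-1 cells (Homo sapiens) for cytotoxicity, read by MTT assay, with a stated time of 72 h (a higher number here means a weaker inhibitor, a lower number a stronger inhibitor), compound 2 gives > 50000 nM, which is a limit and not a number. Going by the values given here, the same holds for compound 1 at > 50000 nM, so the series so far is summed up by the limit of > 50000 nM in this assay, at which 2 of the 2 values shown sit.

The next change leads to compound 3 `O=C(/C=C/c1ccc(C(F)(F)F)cc1)c1c(O)c2ccccc2[nH]c1=O`, with trifluoromethyl in place of carboxy on an aromatic carbon, para to a large group (trifluoromethyl in place of carboxy on an aromatic carbon).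

Among the compounds with values here, the one measured step that bears on this is a step that the two limits leave unreadable from compound 1 to compound 2, and it offers no size to carry over. With no readable step, no clear shift is expected in this assay, and compound 3 is expected to stay at or near the limit. The expected change is an at least 1.1-fold lower number from compound 2 to compound 3 (0.04 log units; that floor lies within the scatter), an estimate with no direction beyond the scatter. For compound 3 the estimated value is 45000 nM, with an expected range from 18000 nM to 50000 nM.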

Compound 3, half-maximal inhibitory concentration: > 50000 nM
Compound 3: a limit, no number (the forecaster's own chance of this, stated with the estimate: 65%); middle value at least 1.1-fold (0.04 log units) away from the limit.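

No step among compound 1, compound 2 and compound 3 can be read, as all three values are one and the same limit: the limit of > 50000 nM in this assay, at which 3 of the 3 values shown sit.

The compounds shown leave open whether nitro, carboxy and trifluoromethyl differ at all in this assay, and which change on the shared core would give a number there.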